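Moving an oxygen one bond outward in a weak EP1 binder

A few compounds are considered here, and "the series" means these few. Any claim that something is new, unique, unknown or untested is made for them only; others in the source may bear on it.

Measured compounds:
- compound 1, `CC(C)(C)CCC1([C@H](O)/C=C/[C@H]2COC(=O)N2CCSc2nc(C(=O)O)cs2)CCC1`: 149 nM
- compound 2, `CC(C)(CCCCF)[C@H](O)/C=C/[C@H]1COC(=O)N1CCSc1nc(C(=O)O)cs1`: 431 nM
- compound 3, `CCOCCC1([C@H](O)/C=C/[C@H]2COC(=O)N2CCSc2nc(C(=O)O)cs2)CCC1`: 8420 nM

All three share one core and differ only in the group carried on the saturated chain carbon that bears the hydroxyl. In an assay on isolated protein for binding affinity to prostaglandin E2 receptor EP1 subtype (Homo sapiens) (on this read-out lower numbers stand for stronger inhibition and higher numbers for weaker inhibition), compound 3 gives the highest number of the three, well beyond the scatter from both others: the step of a 57-fold higher number from compound 1 to compound 3 (1.75 log units; beyond the scatter) and the step of a 20-fold higher number from compound 2 to compound 3 (1.29 log units; beyond the scatter) are both large, while the step of a 2.9-fold higher number from compound 1 to compound 2 (0.46 log units; beyond the scatter) is only modest.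

Compound 4, `COCCCC1([C@H](O)/C=C/[C@H]2COC(=O)N2CCSc2nc(C(=O)O)cs2)CCC1`, keeps every atom of compound 3 but joins them differently: methoxymethyl in place of ethoxy on a saturated chain carbon, two bonds along the chain from a saturated ring carbon. Going by the values given here, no measured step is of this kind; the two large steps above show only that replacing a tert-butyl or a 5-fluoro-1,1-dimethylpentyl by an oxygen-containing chain costs much binding, and that oxygen stays in compound 4. A change of position alone is therefore expected to move this assay little, with the estimated step from compound 3 to compound 4 being a 1.1-fold lower number from compound 3 to compound 4 (0.02 log units; within the scatter). Compound 4 is estimated at 8000 nM, within a range of 2500 nM to 25000 nM.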

Compound 4, inhibition constant: > 10000 nM
Compound 4: no number, only a limit; the forecaster's own chance of this, stated with the estimate: 10%; at least 1.2-fold (0.09 log units) between middle value and limit.
By their numbers in this assay, from the lowest: compound 1; then compound 2; then compound 3. At a limit, above all of these: compound 4.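

In this assay compound 4 gives > 10000 nM, which is a limit of the assay and not a number: the limit of > 10000 nM in this assay, at which 1 of the 4 values shown sits. Turning ethoxy into methoxymethyl, which moves the oxygen one bond outward along the chain, gives an at least 1.1-fold higher number from compound 3 to compound 4 (0.07 log units; that floor lies within the scatter), and that floor cannot tell whether the move itself matters, so it may do little or may cost further binding. What the result does add is that the oxygen-containing chain stays far from the two stronger binders in both of its placements, with an at least 23-fold higher number from compound 2 to compound 4 (1.36 log units; beyond the scatter) and an at least 67-fold higher number from compound 1 to compound 4 (1.82 log units; beyond the scatter).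

As far as these compounds go, it remains open whether the oxygen itself carries the loss or the shape of the chain does. A plain butyl chain in place of 3-methoxypropyl would address this, and an amine in the position of the oxygen would show whether another atom there is tolerated.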